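This account rests on a few compounds, and the source may have more. Where it says the series, first, only, none or still open, it means among the compounds named here.

Working notes on the series. Compound 1 `CC(Sc1nc2c(cnn2C)c(=O)n1-c1ccccc1)c1ccccn1` and compound 2 `CC(Sc1nc2nn(C3COC3)cc2c(=O)n1-c1ccccc1)c1ccccn1` share a pyridin-2-yl bearing side chain but differ in their cores; the difference between the two cores is not broken down here. In a physicochemical assay for solubility, using the shake flask method, in phosphate buffer, with a stated time of 24 h, at pH 7.4 (on this read-out lower numbers stand for lower solubility and higher numbers for higher solubility), compound 1 gives 20000 nM, while compound 2 gives 60000 nM. Compound 3 `CC(Sc1nc2c(cnn2C)c(=O)n1-c1ccccc1)c1cccnc1` carries the core of compound 1 with the change (pyridin-3-yl in place of pyridin-2-yl on a saturated chain carbon bound to a saturated chain carbon and a sulfur), and in this assay compound 3 gives 209000 nM; the resulting step is a 10-fold higher number from compound 1 to compound 3 (1.02 log units; beyond the scatter). Among the measured compounds shown here, compound 4 `CC(Sc1nc2nn(C3COC3)cc2c(=O)n1-c1ccccc1)c1cccnc1` is not yet measured; it carries the core of compound 2 with the change (pyridin-3-yl in place of pyridin-2-yl on a saturated chain carbon bound to a saturated chain carbon and a sulfur), which is the same kind of change, at the same place, as the one from compound 1 to compound 3. For the measured compounds named here, by analogy with that one measured step, compound 4 is expected to show a step of an 8.3-fold higher number from compound 2 to compound 4 (0.92 log units; beyond the scatter) in this assay, resting on the single pair compound 1 to compound 3 and its step of a 10-fold higher number from compound 1 to compound 3 (1.02 log units; beyond the scatter). The estimate for compound 4 in this assay is 500000 nM, with a range from 150000 nM to 1500000 nM.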

Compound 4, solubility: 189000 nM
Estimate against measurement, compound 4: 2.6-fold (0.42 log units) above, and the stated range covers the measured number.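

In this assay the change to pyridin-3-yl from pyridin-2-yl on a saturated chain carbon bound to a saturated chain carbon and a sulfur gives a 3.2-fold higher number from compound 2 to compound 4 (0.50 log units; beyond the scatter) and so runs the same way as a 10-fold higher number from compound 1 to compound 3 (1.02 log units; beyond the scatter) on the core of compound 1. Across these two cores the direction of the step carries over, with both steps beyond the scatter, but the size does not carry over unchanged: it is large on the core of compound 1 and modest on the core of compound 2, and two pairs cannot show how it would run on a further core. Nothing shown here bears on what lies behind the step or behind its different size on the two cores.

The compounds shown leave open whether pyridin-4-yl at the same place would follow the same direction on either core. Also open, from the compounds shown here alone, is how the numbers would run with an amine or a carboxylic acid on the pyridine ring.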